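Penam alkylidene esters: cytotoxicity on OE19 cells

The compounds below may be only part of what the source reports. "The series", "measured", "known", "first", "only" and "open" are said of these compounds alone.

Measured:
compound 1 `CC1(C)S[C@@H]2/C(=C\C(=O)c3ccc4ccccc4c3)C(=O)N2[C@H]1C(=O)OC(c1ccccc1)c1ccccc1` — 19500 nM
compound 2 `CC1(C)[C@H](C(=O)OC(c2ccccc2)c2ccccc2)N2C(=O)/C(=C/C(=O)c3ccc([N+](=O)[O-])cc3)[C@H]2[S+]1[O-]` — 92400 nM

In a functional assay on OE19 cells (Homo sapiens) for cytotoxicity, read by MTT assay, with a stated time of 48 h (a higher number here means a weaker inhibitor, a lower number a stronger inhibitor), compound 1 gives 19500 nM, the lowest of the two numbers; compound 2 gives 92400 nM, a gap beyond the scatter. Among the compounds with values here, no step between measured compounds differing in one place is available, so nothing direct anchors the change to compound 3 `COC(=O)/C=C1/C(=O)N2[C@@H]1SC(C)(C)[C@@H]2C(=O)OC(c1ccccc1)c1ccccc1`. Compound 3 differs from compound 1 by methoxy in place of naphthalen-2-yl on a carbonyl carbon. With the naphthalen-2-yl group leaving for methoxy, a weakening step is expected, a 2.8-fold higher number from compound 1 to compound 3 (0.45 log units; beyond the scatter). Compound 3 is expected to give about 55000 nM, with a range from 15000 nM to 200000 nM.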

Compound 3, half-maximal inhibitory concentration: 20200 nM
The estimate for compound 3 lay 2.7-fold (0.44 log units) above the measured number; measured number inside the range.
By their numbers in this assay, from the lowest: compounds 1 and 3 (each within the scatter of the next); then compound 2.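

Replacing naphthalen-2-yl with methoxy on a carbonyl carbon gives a 1.0-fold higher number from compound 1 to compound 3 (0.02 log units; within the scatter) in this assay and shows that this position tolerates the change. The large aromatic group is therefore not needed to hold the cytotoxicity of compound 1 in this assay, and a methoxycarbonyl serves equally well here. No independent data on these compounds explain this outcome.

Going by these compounds, it remains open whether a dimethylamino group or a hydroxyl at this carbonyl carbon would keep this level. A phenyl or a longer ethoxy or butoxy group there is equally untested in the compounds shown.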